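Losing the Branched Alcohol Side Chain

The source may report more compounds than this note shows. Statements on the series, on what has been measured and on what is new or still open speak of the compounds shown alone.

Measured so far in a functional assay on PC-3 cells (Homo sapiens) for antiproliferative activity, read by MTT assay, with a stated time of 24 h; on this read-out lower numbers stand for stronger inhibition and higher numbers for weaker inhibition
Compound 1 `CCn1c(C(=O)N[C@H](C)C(=O)OC)ccc1C(CC)(CC)c1ccc(OCS(=O)(=O)c2ccccc2)c(C)c1` gives > 50000 nM as a limit
Compound 2 `CCn1c(C(=O)NCCC(=O)OC)ccc1C(CC)(CC)c1ccc(OCS(=O)(=O)c2ccccc2)c(C)c1` gives 40400 nM as a number
Compound 3 `CCn1c(C(=O)N[C@@H](CO)C(C)C)ccc1C(CC)(CC)c1ccc(OCS(=O)(=O)c2ccccc2)c(C)c1` gives 10600 nM as a number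

Compound 3 (10600 nM) has the lower of the two true numbers. Compound 4 `CCn1c(C(=O)N[C@H](C)C(=O)O)ccc1C(CC)(CC)c1ccc(OCS(=O)(=O)c2ccccc2)c(C)c1` differs from it by one change 1-carboxyethyl in place of 1-(hydroxymethyl)-2-methylpropyl on an amide-type nitrogen that puts 1-carboxyethyl in place of 1-(hydroxymethyl)-2-methylpropyl on an amide-type nitrogen. Within the data shown here, two measured steps bear on this, both arriving at the group now leaving: an at least 4.7-fold lower number from compound 1 to compound 3 (0.67 log units; beyond the scatter) and a 3.8-fold lower number from compound 2 to compound 3 (0.58 log units; beyond the scatter) are each beyond the scatter. Among the measured compounds shown here, removing that group should give back part of this gain, although no measured step shows the carboxyl-bearing group itself. The expected step is a 2.8-fold higher number from compound 3 to compound 4 (0.45 log units; beyond the scatter) towards weaker inhibition. Compound 4 is estimated at 30000 nM with 11000 nM and 50000 nM as the ends of its expected range.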

Compound 4, half-maximal inhibitory concentration: 20100 nM
The estimate for compound 4 lay 1.5-fold (0.17 log units) above the measured number; low and high end bracket the measured number.
By their numbers in this assay, from the lowest: compounds 3, 4 and 2 (each within the scatter of the next, the first and the last beyond it). At a limit, above all of these: compound 1.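

At this amide-type nitrogen, compound 4 cannot be told apart from either neighbour, with a 1.9-fold higher number from compound 3 to compound 4 (0.28 log units; within the scatter) and a 2.0-fold lower number from compound 2 to compound 4 (0.30 log units; within the scatter). Hydrogen in place of methyl on an oxygen next to a carbonyl group, the one change between compound 1 and compound 4, gives an at least 2.4-fold lower number from compound 1 to compound 4 (0.39 log units; beyond the scatter). The value of compound 1 is a limit, and this step is only a floor: the limit of > 50000 nM in this assay, at which 1 of the 4 values shown sits.

The compounds shown leave open how an amine on this side chain, or 2-carboxyethyl, the free acid matching compound 2, would compare.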